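The source may report more compounds than this note shows. Statements on the series, on what has been measured and on what is new or still open speak of the compounds shown alone.

Working notes on the series, all sharing one core and read in an ADME assay on L6 cells (Rattus norvegicus) for cytotoxicity; a lower number here means a stronger inhibitor, a higher number a weaker inhibitor. Compound 1 (`CCN(CC)CC(=O)OC1CC2(N3CCCC3)CC(c3ccccc3)C1C(c1ccccc1)C2`) gives 49000 nM, compound 2 (`O=C(CN1CCCCC1)OC1CC2(N3CCCC3)CC(c3ccccc3)C1C(c1ccccc1)C2`) gives 14200 nM, and compound 3 (`O=C(CCN1CCCC1)OC1CC2(N3CCCC3)CC(c3ccccc3)C1C(c1ccccc1)C2`) gives 21900 nM. Two steps place the last of these: a 1.5-fold higher number from compound 2 to compound 3 (0.19 log units; within the scatter) and a 2.2-fold lower number from compound 1 to compound 3 (0.35 log units; beyond the scatter).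

Compound 4 (`O=C(CCN1CCCCC1)OC1CC2(N3CCCC3)CC(c3ccccc3)C1C(c1ccccc1)C2`) keeps the chain of compound 3 and changes only the terminal ring: piperidin-1-yl in place of pyrrolidin-1-yl on a saturated chain carbon, two bonds along the chain from a carbonyl carbon. In words, this is piperidin-1-yl in place of pyrrolidin-1-yl on a saturated chain carbon, two bonds along the chain from a carbonyl carbon.

Among the compounds with values here, no measured pair makes exactly this swap, so the evidence is indirect. The closest step that introduces piperidin-1-yl is a 3.5-fold lower number from compound 1 to compound 2 (0.54 log units; beyond the scatter), but it replaces diethylamino rather than pyrrolidin-1-yl. Within the data shown here, the only measured step between the two ring types is a 1.5-fold higher number from compound 2 to compound 3 (0.19 log units; within the scatter), and it alters the chain as well. Together these suggest at most a slight lean towards a lower number in this assay, and no step beyond the scatter is expected. The estimated step is a 1.2-fold lower number from compound 3 to compound 4 (0.09 log units; within the scatter). For compound 4 the estimated value is 18000 nM, with an expected range of 9000 nM to 36000 nM.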

Compound 4, half-maximal inhibitory concentration: 17800 nM
Compound 4: the middle estimate sits 1.0-fold (0.00 log units) above what was measured; measured number inside the range.
By their numbers in this assay, from the lowest: compounds 2, 4 and 3 (each within the scatter of the next); then compound 1.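

In this assay, the ring swap on a saturated chain carbon, two bonds along the chain from a carbonyl carbon, is now read directly as a 1.2-fold lower number from compound 3 to compound 4 (0.09 log units; within the scatter) and does not separate piperidin-1-yl from pyrrolidin-1-yl on this chain. Within the data shown here, with piperidin-1-yl kept, going to (piperidin-1-yl)methyl gives a 1.3-fold higher number from compound 2 to compound 4 (0.10 log units; within the scatter) and so also stays within the scatter, which leaves compounds 2, 3 and 4 as one group for these changes of ring and chain, whereas the earlier compounds offered only a step that altered both at once. Compound 1 alone stands apart from that group, and a 2.8-fold lower number from compound 1 to compound 4 (0.44 log units; beyond the scatter) adds a third cyclic amine comparison to the two already read against its diethylamino group, while no measurement on hand bears on why these numbers fall as they do.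

Going by these compounds, whether diethylamino on the 2-substituted ethyl chain of compounds 3 and 4 would keep compound 1's distance from the group remains open. Also open, on these data alone, is whether morpholin-4-yl, azepan-1-yl or a longer chain at this position would stay within the scatter of compounds 2, 3 and 4.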